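Swapping the Amine Substituent in an Acid Ceramidase Series

A few compounds are considered here, and "the series" means these few. Any claim that something is new, unique, unknown or untested is made for them only; others in the source may bear on it.

Two compounds have been measured:
- Compound 1 `CN1CCN(c2ccc3c(c2)oc(=O)n3C(=O)NCCCCc2ccccc2)CC1=O` gives 92 nM in an assay on HEK293 cells for inhibition of acid ceramidase (Homo sapiens), read by fluorescence, with stated times of 10 min and 3 h; on this read-out higher numbers stand for weaker inhibition and lower numbers for stronger inhibition.
- Compound 2 `CN1CCC(c2ccc3c(c2)oc(=O)n3C(=O)NCCCCc2ccc(F)cc2)CC1` gives 94 nM in this assay.

Compound 1 has the lower of the two numbers, but the value of compound 2 sits so close to it that the two lie within the usual scatter, so no order between them can be claimed. Both carry the same shared core and a four-carbon chain ending in a phenyl ring, with compound 2 also bearing a fluorine on that ring and a different substituent on the core.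

Compound 3 `CC(C)N1CCC(c2ccc3c(c2)oc(=O)n3C(=O)NCCCCc2ccccc2)CC1` has not yet been measured. It differs from compound 1 in one place: 1-isopropylpiperidin-4-yl in place of 4-methyl-3-oxopiperazin-1-yl on an aromatic carbon. Going by the values given here, no step between two measured compounds isolates this change, so there is no direct precedent for its size. Compound 2, which also carries a piperidinyl substituent at that position, reaches a similar number, which suggests the change is tolerated. The step of a 1.2-fold lower number from compound 1 to compound 3 (0.06 log units; within the scatter) is therefore expected to stay within the scatter, with no clear direction. Compound 3 is estimated at 80 nM, with a range from 30 nM to 250 nM.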

Compound 3, half-maximal inhibitory concentration: 94 nM
Beside the measured number, compound 3's estimate is 1.2-fold (0.07 log units) below it, and the stated range covers the measured number.
By their numbers in this assay, from the lowest: compounds 1, 2 and 3 (each within the scatter of the next).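

In this assay, going by these compounds alone, putting 1-isopropylpiperidin-4-yl in place of 4-methyl-3-oxopiperazin-1-yl gives a 1.0-fold higher number from compound 1 to compound 3 (0.01 log units; within the scatter), the first reading of a change at this aromatic carbon with the rest of the molecule held constant. The two groups differ on paper: the entering one has no oxygen, no double bond outside aromatic rings and 1 hydrogen-bond acceptor rather than 2, yet no order can be claimed between compound 1 and compound 3, so for this pair, the read-out does not separate the two six-membered rings. No measurement shown here explains why the two groups read alike.

This single pair cannot show how far that holds, since both groups are six-membered rings containing nitrogen, and a carboxylic acid or an open-chain dimethylamino group on the same aromatic carbon could read quite differently. Going by these compounds, it also remains open whether the isopropyl group on the ring nitrogen of compound 3 matters, a question that a version with a cyclopropyl group or a bare amine hydrogen there could address.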